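The compounds below may be only part of what the source reports. "The series", "measured", "known", "first", "only" and "open" are said of these compounds alone.

Compound 1 `O=C(Nc1ccc(Cl)c(-c2nnc3c(Cl)cccn23)c1)c1ccc(C(F)(F)F)cc1F`: 70800 nM
Compound 2 `CS(=O)(=O)c1ccc(C(=O)Nc2ccc(Cl)c(-c3nnc4c(Cl)cccn34)c2)cc1`: > 100000 nM

In a functional assay on T47D cells (Homo sapiens) for antiproliferative activity, read by MTT assay, with a stated time of 72 h (a lower number here means a stronger inhibitor, a higher number a weaker inhibitor), compound 1 gives 70800 nM. Compound 2 gives only > 100000 nM, which is a limit of the measurement and not a number. Compound 2 therefore stands at the limit of > 100000 nM in this assay, at which 1 of the 2 values shown sits. Compound 3 `O=C(Nc1ccc(Cl)c(-c2nnc3c(Cl)cccn23)c1)c1ccccc1Cl` carries 2-chlorophenyl in place of 4-(methylsulfonyl)phenyl on a carbonyl carbon. Among the compounds with values here, no measured pair shows a change of this kind. The step from compound 2 to compound 3 is expected to be an at least 1.6-fold lower number from compound 2 to compound 3 (0.22 log units; that floor lies within the scatter), toward the stronger side, though it may not reach beyond the usual scatter. Compound 3 is expected to give 60000 nM, most likely between 20000 nM and 150000 nM.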

Compound 3, half-maximal inhibitory concentration: 83800 nM
Compound 3: the middle estimate sits 1.4-fold (0.15 log units) below what was measured; the measured number falls inside the stated range.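

In this assay, compound 2 has a limit of the measurement and not a number: the limit of > 100000 nM in this assay, at which 1 of the 3 values shown sits. Putting 2-chlorophenyl in place of 4-(methylsulfonyl)phenyl on the carbonyl carbon can therefore be read only as a floor, an at least 1.1-fold lower number from compound 2 to compound 3 (0.07 log units; that floor lies within the scatter), and that floor lies within the usual scatter. On these data alone, compound 3 thus gives this position a second measured number alongside compound 1, while the true size of the change stays unknown. As far as these compounds go, what an amine or a carboxylic acid would do in place of these rings on the carbonyl carbon remains open. So does whether any group here can bring the number much lower.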